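Methyl in Place of Hydrogen on the Shared Aromatic Ring

A few compounds are considered here, and "the series" means these few. Any claim that something is new, unique, unknown or untested is made for them only; others in the source may bear on it.

Compound 1 `C1=NCC(CC2=Cc3ccccc3CC2)N1` serves as the point of reference. In a functional assay for binding affinity to Norepinephrine transporter (Rattus norvegicus), read by radioligand binding, in the presence of a further agent that is not named here (on this read-out higher numbers stand for weaker inhibition and lower numbers for stronger inhibition), compound 1 gives 50.1 nM. Two analogues carry a single substituent on an aromatic carbon of the shared core: compound 2 `Clc1cccc2c1C=C(CC1CN=CN1)CC2`, which gives 50.1 nM in this assay, and compound 3 `Fc1ccc2c(c1)C=C(CC1CN=CN1)CC2`, which gives 50.1 nM in this assay. The step of no change at the digits printed from compound 1 to compound 2 (within the scatter) and the step of no change at the digits printed from compound 1 to compound 3 (within the scatter) both lie within the scatter, so compound 1 stands level with compound 2 and compound 3 on the numbers shown; neither the chloro nor the fluoro substituent moved the read-out beyond it.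

Compound 4 `Cc1ccc2c(c1)CCC(CC1CN=CN1)=C2` extends this series with a different substituent. The change from compound 1 to compound 4 is methyl in place of hydrogen on an aromatic carbon. The two measured steps that bear on it, from compound 1 to compound 2 and from compound 1 to compound 3, were both flat, and each replaced a hydrogen on an aromatic carbon with a small group, as the methyl does here. On that basis the step of a 1.0-fold lower number from compound 1 to compound 4 (0.00 log units; within the scatter) is expected to stay within the scatter in this assay, with no direction favoured. Compound 4 is therefore estimated at 50 nM in this assay, with a range from 25 nM to 100 nM.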

Compound 4, inhibition constant: < 1000 nM
Compound 4 was reported as a limit; the forecaster's own chance of this, stated with the estimate: 5%; the middle value is on the limit's open side.
By their numbers in this assay, from the lowest: compounds 1, 2 and 3 (each within the scatter of the next).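

In this assay, compound 4 is reported only as a limit, < 1000 nM. Going by these compounds alone, the step between compound 1 and compound 4 therefore cannot be read, and no new step arises. The compounds shown leave open whether methyl in place of hydrogen on an aromatic carbon changes the read-out relative to compound 1.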